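Removing a Benzyl Group: Expected Effect on Glioma Cell Growth

This account rests on a few compounds, and the source may have more. Where it says the series, first, only, none or still open, it means among the compounds named here.

Compound 1 `COc1cc(OC)c2cc(-c3ccc(OCc4ccccc4)cc3)c(O)nc2c1` was measured in a functional assay on U-87MG ATCC cells for cytotoxicity against U-87 MG (Homo sapiens), read by colorimetric assay and MTT assay (on this read-out lower numbers stand for stronger inhibition and higher numbers for weaker inhibition), and gives 10000 nM.
Compound 2 `COc1ccc(-c2cc3c(OC)cc(OC)cc3n(CC(=O)OCc3ccccc3)c2=O)cc1` in this assay gives 10000 nM.
Compound 3 `COc1ccc(-c2cc3c(OC)cc(OC)cc3n(CC(=O)O)c2=O)cc1` in this assay gives 10000 nM.

The three measured compounds sit level with one another in this assay; none of them can be called more or less active than the others. Compound 2 and compound 3 share a core and differ by hydrogen in place of benzyl on an oxygen next to a carbonyl group, a change that gave no change at the digits printed from compound 2 to compound 3 (within the scatter). Compound 1 has a different core from compound 2, and the difference between the two cores is not broken down here; their values simply show no gap within the usual scatter.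

Compound 4 `COc1cc(OC)c2cc(-c3ccc(O)cc3)c(O)nc2c1` is not yet measured. It differs from compound 1 by hydrogen in place of benzyl on an oxygen on an aromatic ring. Among the compounds with values here, this is the same kind of change as the one between compound 2 and compound 3, but not the same: there the benzyl left an oxygen next to a carbonyl group whose other neighbour is a carbonyl carbon, whereas here it leaves an oxygen on an aromatic ring whose other neighbour is an aromatic carbon.

The expectation for compound 4 rests on the earlier step and on compound 1 itself, which gives 10000 nM. The step from compound 1 to compound 4 is expected to be no change at the digits printed from compound 1 to compound 4 (within the scatter), placed beside the earlier step because no change at the digits printed from compound 2 to compound 3 (within the scatter) was seen when the benzyl was removed. Compound 4 is therefore estimated at 10000 nM, with a range from 4000 nM to 25000 nM.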

Compound 4, half-maximal inhibitory concentration: 10000 nM
Beside the measured number, compound 4's estimate shows no gap at the digits printed, within the range that was stated.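

In this assay, putting hydrogen in place of benzyl on an oxygen on an aromatic ring gave no change at the digits printed from compound 1 to compound 4 (within the scatter), so compound 4 stands level with compound 1. Set beside the removal of benzyl on the other core, the result is the same, and the step carries across these two cores without a gap: the same change on two cores in this assay, no change at the digits printed (within the scatter) from compound 2 to compound 3 and no change at the digits printed (within the scatter) from compound 1 to compound 4, 1.0-fold (0.00 log units) apart, within the scatter of two such steps. Within the data shown here, this does not show that the change is neutral in general, since the two steps act at different places, one on an oxygen next to a carbonyl group and the other on an oxygen on an aromatic ring, and all four compounds print the same value, which leaves no step here starting from a compound with a lower number.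

The compounds shown leave open whether an amine in place of the hydroxy of compound 4, or a longer chain such as hexyl on that oxygen, would move the read-out away from this shared level. They also leave open whether an amide in place of the carboxylic acid of compound 3 would stay level with it.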